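This account rests on a few compounds, and the source may have more. Where it says the series, first, only, none or still open, it means among the compounds named here.

Measured so far:
Compound 1, `CC(C)c1ncn2c(S)nncc12`: > 48000 nM
Compound 2, `Sc1nncc2cncn12`: > 48000 nM

In a functional assay for inhibition, with Homo sapiens as the target (on this read-out lower numbers stand for stronger inhibition and higher numbers for weaker inhibition), compound 1 reports > 48000 nM, which is a limit of the assay and not a number. In this assay compound 2 reports > 48000 nM, again a limit. Both values sit at the limit of > 48000 nM in this assay, at which 2 of the 2 values shown sit, so compound 2 stands at the same place as compound 1, and the step that the two limits leave unreadable from compound 1 to compound 2, hydrogen in place of isopropyl on an aromatic carbon, cannot be sized from the two limits.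

Compound 3, `CCc1ncn2c(S)nncc12`, is still to be measured in this assay. It differs from compound 2 by ethyl in place of hydrogen on an aromatic carbon. Within the data shown here, the only measured step that bears on this change is a step that the two limits leave unreadable from compound 1 to compound 2, which alters the same aromatic carbon, but its size is not readable. Because compound 2 sits at the limit of > 48000 nM in this assay, at which 2 of the 2 values shown sit, compound 3 is expected to sit at that limit as well, so the expected step that the limit leaves unreadable from compound 2 to compound 3 is one that the assay is unlikely to resolve. The estimate for compound 3 in this assay is 100000 nM, with a range from 20000 nM to 500000 nM.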

Compound 3, half-maximal inhibitory concentration: > 48000 nM
Compound 3: only a limit was reported; the forecaster's own chance of this, stated with the estimate: 85%; the middle value is on the limit's open side.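

No new step can be read among compound 1, compound 2 and compound 3, because all three report the same assay limit rather than a number: the limit of > 48000 nM in this assay, at which 3 of the 3 values shown sit. Going by these compounds, how strongly any of them inhibits in this assay and whether hydrogen, ethyl or isopropyl on that aromatic carbon makes any difference both stay open.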